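Removing the Methoxy Group from Compound 3

This account rests on a few compounds, and the source may have more. Where it says the series, first, only, none or still open, it means among the compounds named here.

Compound 3 `COc1ccccc1C(=O)Nc1ccc(Sc2nc3ccccc3s2)c(Cl)c1` stands at the weak end of the series: in an assay for inhibition of HSP60/HSP10 (Homo sapiens), with a stated time of 60 min (a lower number here means a stronger inhibitor, a higher number a weaker inhibitor), compound 3 gives only > 100000 nM, which is a limit of the assay rather than a measured number. Compound 1 `O=C(Nc1ccc(Sc2nc3ccccc3s2)c(Cl)c1)c1cccc(Br)c1O` gives 6900 nM in this assay. Compound 2 `O=C(Nc1ccc(Sc2nc3ccccc3s2)c(Cl)c1)c1cc(Br)cc(Br)c1O` gives 4200 nM in this assay. The step of a 1.6-fold lower number from compound 1 to compound 2 (0.22 log units; within the scatter) is small, whereas an at least 14-fold higher number from compound 1 to compound 3 (1.16 log units; beyond the scatter) and an at least 23-fold higher number from compound 2 to compound 3 (1.37 log units; beyond the scatter) are both large losses, and these two steps are the ones that bear on the next change. Compound 4 `O=C(Nc1ccc(Sc2nc3ccccc3s2)c(Cl)c1)c1ccccc1` differs from compound 3 by hydrogen in place of methoxy on an aromatic carbon. Among the measured compounds shown here, no measured pair shows exactly this change. Both measured compounds that inhibit carry a 3-bromo-2-hydroxyphenyl or a 3,5-dibromo-2-hydroxyphenyl, and compound 4 carries neither of them nor the methoxy of compound 3. Compound 4 is therefore expected to remain weak, with a step of about a number no higher from compound 3 to compound 4 (the limit leaves the size open) and no clear move beyond the scatter. Compound 4 is estimated at 100000 nM in this assay, within a range from 20000 nM to 400000 nM.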

Compound 4, half-maximal inhibitory concentration: > 100000 nM
Compound 4 gave a limit, no number; the forecaster's own chance of this, stated with the estimate: 60%; the middle value sits exactly at the limit.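

In this assay compound 4 gives > 100000 nM as a limit of the assay and not a number. The step between compound 3 and compound 4 cannot be read, because both compounds end at the same limit: the limit of > 100000 nM in this assay, at which 2 of the 4 values shown sit. What this adds is that removing the methoxy group does not bring back measurable inhibition: the plain phenyl gives an at least 14-fold higher number from compound 1 to compound 4 (1.16 log units; beyond the scatter) and an at least 23-fold higher number from compound 2 to compound 4 (1.37 log units; beyond the scatter) so the large loss seen with the 2-methoxyphenyl also appears when that ring carries no group at all.

The compounds shown leave open whether a 2-hydroxyphenyl without any bromo inhibits, and whether bromo alone on a ring without the hydroxy group does. They also leave open whether an amine or a carboxylic acid in place of the hydroxy group would keep inhibition.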